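The source may hold more compounds than are shown below. What is called first, only, known or untested is meant among the compounds shown, and "the series" means these compounds.

Values measured in a functional assay on DU-145 cells (Homo sapiens) for cytotoxicity, read by sulforhodamine B assay, with a stated time of 48 h; on this read-out higher numbers stand for weaker inhibition and lower numbers for stronger inhibition:

- compound 1 `C[C@H]1CC[C@@H]2[C@@H](OC(=O)[C@]23CC(c2ccccc2Br)=NO3)[C@]2(C)C(=O)C=C[C@@]12O`: 18000 nM
- compound 2 `COc1ccc(C2=NO[C@]3(C2)C(=O)O[C@@H]2[C@H]3CC[C@H](C)[C@]3(O)C=CC(=O)[C@@]23C)cc1OC`: 84000 nM
- compound 3 `C[C@H]1CC[C@@H]2[C@@H](OC(=O)[C@]23CC(c2ccccc2F)=NO3)[C@]2(C)C(=O)C=C[C@@]12O`: 24000 nM

These three compounds share a core and differ in the aromatic group they carry. Compound 3, at 24000 nM, cannot be told apart from compound 1, as a 1.3-fold higher number from compound 1 to compound 3 (0.12 log units; within the scatter) lies within the scatter. Compound 2 stands clearly higher, with a 3.5-fold lower number from compound 2 to compound 3 (0.54 log units; beyond the scatter).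

The next compound to be measured is compound 4 `Cc1ccccc1C1=NO[C@]2(C1)C(=O)O[C@@H]1[C@H]2CC[C@H](C)[C@]2(O)C=CC(=O)[C@@]12C`. It has one change from compound 3: methyl in place of fluoro on an aromatic carbon. In words, this is methyl in place of fluoro on an aromatic carbon, turning 2-fluorophenyl into 2-methylphenyl.

The closest guide is a 1.3-fold higher number from compound 1 to compound 3 (0.12 log units; within the scatter), which also exchanges one small group on that aromatic ring and made no difference beyond the scatter. Larger numbers appear only when the aromatic group is more heavily altered, as in a 4.7-fold higher number from compound 1 to compound 2 (0.67 log units; beyond the scatter), and even that step is modest. Going by the values given here, no measured compound carries a methyl group on this ring, so the expectation remains uncertain.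

In this assay, no shift beyond the scatter is expected, and the estimate is a 1.0-fold lower number from compound 3 to compound 4 (0.02 log units; within the scatter). The estimated value for compound 4 is 23000 nM, with an expected range from 11000 nM to 50000 nM.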

Compound 4, half-maximal inhibitory concentration: 12000 nM
Compound 4: the middle estimate sits 1.9-fold (0.28 log units) above what was measured; the measured number falls inside the stated range.
By their numbers in this assay, from the lowest: compounds 4, 1 and 3 (each within the scatter of the next); then compound 2.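

Going by these compounds alone, the methyl group is the first carbon group seen at this place on the ring, and its step from fluoro lies within the scatter (a 2.0-fold lower number from compound 3 to compound 4 (0.30 log units; within the scatter)), as does its step from bromo (a 1.5-fold lower number from compound 1 to compound 4 (0.18 log units; within the scatter)). In this assay, then, fluoro, bromo and methyl on this aromatic carbon cannot be told apart, so the tolerance seen between the two halogens now extends to a group that is not a halogen. Compound 2, with its 3,4-dimethoxyphenyl group, goes against this grouping and stays apart, now with the largest step of the set (a 7.0-fold lower number from compound 2 to compound 4 (0.85 log units; beyond the scatter)), which is modest but beyond the scatter.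

Going by these compounds, it remains open whether an amine, a hydroxyl or a carboxylic acid on this aromatic carbon would stay with these three compounds, and whether the gap to compound 2 follows from the number of methoxy groups or from where they sit. No available data explain why fluoro, bromo and methyl give such similar results here.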